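This account rests on a few compounds, and the source may have more. Where it says the series, first, only, none or still open, it means among the compounds named here.

Compound 1 `Cc1nc(C(c2ccc(-c3ccc4cccc(F)c4c3)[nH]c2=O)C(C)C)[nH]c1C`: 0.0733 h
Compound 2 `CC(C)C(c1ccc(-c2ccc3cccc(F)c3c2)[nH]c1=O)N1CCNC1=O`: 0.283 h
Compound 3 `CC(C)C(/C=C1/CCNC1=O)c1ccc(-c2ccc3cccc(F)c3c2)[nH]c1=O`: 0.06 h

All three compounds were tested in an ADME assay on microsomes from liver (Rattus norvegicus) for metabolic stability; on this read-out higher numbers stand for a longer-lived compound and lower numbers for a shorter-lived compound. Compound 3 gives 0.06 h, and the step of a 1.2-fold lower number from compound 1 to compound 3 (0.09 log units; within the scatter) shows it level with compound 1. Compound 2 stands apart from both, with a 3.9-fold higher number from compound 1 to compound 2 (0.59 log units; beyond the scatter) and a 4.7-fold lower number from compound 2 to compound 3 (0.67 log units; beyond the scatter).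

Compound 4 `CC(C)C(/C=C1\CCNC1=O)c1ccc(-c2ccc3cccc(F)c3c2)[nH]c1=O` is the next to be considered. Its relation to compound 3 is simple: the two compounds have the same atoms and bonds; at least one stereo element is drawn with a configuration in one of them and without one in the other: 1 of 2 stereo elements differ; a double bond is drawn Z in compound 3 and E in compound 4. In plain terms, a double bond is drawn Z in compound 3 and E in compound 4, and nothing else differs.

Going by the values given here, none of the measured steps is a change of this kind. Each one swaps a whole group for another, so they show only what such swaps did here, from a step within the scatter to a modest one. They say nothing direct about a switch from Z to E. Three compounds are also a thin basis, so the range has to stay wide. With no evidence for either direction, and with compound 3 at 0.06 h, the expectation in this assay is that compound 4 stays close to that value. The estimated step is a 1.2-fold higher number from compound 3 to compound 4 (0.07 log units; within the scatter), and no change beyond the scatter is expected. Compound 4 is expected at 0.07 h, with an estimated range of 0.03 h to 0.18 h.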

Compound 4, half-life: 0.345 h
Compound 4: the middle estimate sits 4.9-fold (0.69 log units) below what was measured, outside the stated range (above it).
By their numbers in this assay, from the lowest: compounds 3 and 1 (each within the scatter of the next); then compounds 2 and 4 (each within the scatter of the next).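

In this assay the geometry of the double bond alone carries a step beyond the scatter: a 5.8-fold higher number from compound 3 to compound 4 (0.76 log units; beyond the scatter). The atoms and bonds stay the same here, whereas every earlier step swapped a whole group, so at this position the drawn geometry of the attached ring counts as well as the identity of the group. The E form is level with the 2-oxoimidazolidin-1-yl group in a 1.2-fold higher number from compound 2 to compound 4 (0.09 log units; within the scatter) and clear of the 4,5-dimethyl-1H-imidazol-2-yl group in a 4.7-fold higher number from compound 1 to compound 4 (0.67 log units; beyond the scatter), so the earlier picture of this ring matching the imidazole and falling short of the 2-oxoimidazolidin-1-yl group holds only for compound 3, with one caution on the comparison of the two forms: the fact that one of compounds 3 and 4 is drawn with a defined configuration and the other without, at the place where they differ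

The compounds shown leave open whether the Z and E forms would stay as far apart with a six-membered lactam or an open-chain amide in place of the five-membered ring. They also leave open where a saturated link with no double bond at all would fall relative to compound 3 and compound 4.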